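Indolylthio-pyrimidine ureas: anilino in place of cyclopropylamino

This account rests on a few compounds, and the source may have more. Where it says the series, first, only, none or still open, it means among the compounds named here.

Three measured members of the series share the core shown beside compound 1 `Cc1cc(Cl)ccc1NC(=O)Nc1nc(Sc2c[nH]c3ccccc23)cc(N2CCN(Cc3ccccc3)CC2)n1`, which in a functional assay on MDA-MB-231 cells (Homo sapiens) for inhibition, with a stated time of 72 h (on this read-out higher numbers stand for weaker inhibition and lower numbers for stronger inhibition), gives 22100 nM. Compound 2 `COc1ccc(NC(=O)Nc2nc(Sc3c[nH]c4ccccc34)cc(N3CCCCC3)n2)cc1` gives 7260 nM in this assay, and compound 3 `O=C(Nc1ccccc1)Nc1nc(NC2CC2)cc(Sc2c[nH]c3ccccc23)n1` gives 7860 nM. Compound 3 thus stands second highest of the three numbers: its number and that of compound 2 lie within the scatter of each other, while compound 1 gives a higher number than compound 3 by a margin beyond the scatter.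

Compound 4 `O=C(Nc1ccccc1)Nc1nc(Nc2ccc(Cl)cc2)cc(Sc2c[nH]c3ccccc23)n1` differs from compound 3 in one place: 4-chlorophenyl in place of cyclopropyl on a nitrogen on an aromatic ring. For the measured compounds named here, no measured pair carries this change, so its size cannot be read from the data. The expectation is a modest move toward a lower number, of a size that may only just clear the scatter, expressed by the estimated step of a 1.7-fold lower number from compound 3 to compound 4 (0.24 log units; within the scatter). Compound 4 is therefore expected to give about 4500 nM in this assay, within a range from 1500 nM to 16000 nM.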

Compound 4, half-maximal inhibitory concentration: 10300 nM
Estimate against measurement, compound 4: 2.3-fold (0.36 log units) below, and the stated range covers the measured number.
By their numbers in this assay, from the lowest: compounds 2, 3 and 4 (each within the scatter of the next); then compound 1.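

For the compounds shown here, on the nitrogen on the aromatic ring, the replacement of cyclopropyl by 4-chlorophenyl gives the first step that can be read in one place (a 1.3-fold higher number from compound 3 to compound 4 (0.12 log units; within the scatter)) in this assay. This step lies within the scatter, so compound 3 and compound 4 cannot be told apart on this read-out. At this position, then, a six-membered aromatic ring carrying chlorine and a three-membered non-aromatic ring are both compatible with numbers of the same size. Nothing available bears on why the change leaves the number within the scatter. On these data alone, whether this tolerance extends to a morpholine, a carboxylic acid or a longer alkyl chain on this nitrogen stays open. Also open, as far as these compounds go, is whether an unsubstituted phenyl on this nitrogen would sit with compound 3 and compound 4.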